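Tetrazole in Place of Nitrile on an Acetophenone Side Chain

A few compounds are considered here, and "the series" means these few. Any claim that something is new, unique, unknown or untested is made for them only; others in the source may bear on it.

Compound 1 `C=CCc1cc(C(C)=O)c(O)cc1OCCCCCC#N`: 81%
Compound 2 `CCc1cc(C(C)=O)c(O)cc1OCCCC(C)(C)C#N`: 85%

Of the compounds shown here, two have been measured in an assay on isolated protein for inhibition of leukotriene B4 receptor 1 (Homo sapiens), tested at 10 uM (a higher number here means more inhibition at the concentration tested (going by the name of the read-out), a lower number less inhibition), so far. Compound 1 gives 81%, and compound 2 gives 85%. The two numbers lie within the usual scatter of each other, so neither compound can be set apart from the other on this evidence; compound 2 simply stands at a high level of inhibition alongside compound 1.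

Compound 3 `CCc1cc(C(C)=O)c(O)cc1OCCCC(C)(C)c1nnn[nH]1` has not yet been measured. It differs from compound 2 by 1H-tetrazol-5-yl in place of cyano on a saturated chain carbon bound to three saturated chain carbons. For the measured compounds named here, no step between measured compounds exists here to guide the expectation, so the estimate rests on the high readings of compound 1 and compound 2 alone. A step of a number 3 percentage points higher from compound 2 to compound 3 (within the scatter) in this assay is expected for compound 3, that is, no change beyond the scatter or at most a slight rise. Compound 3 is therefore estimated at 88%, with a likely range from 70% to 98%.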

Compound 3, a percentage reported as inhibition, at one concentration (the size of the read-out at that concentration, not a potency): 100%
Estimate against measurement, compound 3: 12 percentage points below, and the stated range ends below it.
By their numbers in this assay, from the lowest: compounds 1 and 2 (each within the scatter of the next); then compound 3.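

In this assay, for the compounds shown here, the exchange of cyano for 1H-tetrazol-5-yl on a saturated chain carbon bound to three saturated chain carbons gives a number 15 percentage points higher from compound 2 to compound 3 (beyond the scatter) and is the only step here that can be read. It shows that the nitrile is not needed at this position for inhibition at the concentration tested, since compound 3 reaches 100% with a five-membered aromatic ring with 4 hetero atoms in its place. Nothing at hand explains the rise.

Going by these compounds, whether a carboxylic acid or a primary amide on the same carbon would give a similar reading remains open. On these data alone, a reading at one concentration is also not a potency, so how far compound 3 and compound 2 differ in potency stays unknown.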